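Double-bond configuration and cytotoxicity: compound 3 to compound 4

A few compounds are considered here, and "the series" means these few. Any claim that something is new, unique, unknown or untested is made for them only; others in the source may bear on it.

- compound 1 `COc1ccc(/C=C/c2c(CC=C(C)C)c(O)cc3c2CC(O)C(C)(C)O3)cc1` gives 1800 nM
- compound 2 `C=CC(C)(C)c1cc(/C=C/c2cc(OC)cc(OC)c2)ccc1OC` gives > 10000 nM (a limit)
- compound 3 `COc1cc(/C=C\c2ccc(OC)c(CC=C(C)C)c2)cc(OC)c1` gives > 10000 nM (a limit)

All three values come from an ADME assay on THP-1 cells (Homo sapiens) for cytotoxicity, read by WST assay, with a stated time of 24 h; on this read-out higher numbers stand for weaker inhibition and lower numbers for stronger inhibition. Compound 3 stands at the limit of > 10000 nM in this assay, at which 2 of the 3 values shown sit, so it has a limit and no number. The next compound, compound 4 `COc1cc(/C=C/c2ccc(OC)c(CC=C(C)C)c2)cc(OC)c1`, is not yet measured. The change is the two compounds have the same atoms and bonds and differ only in configuration as drawn: 1 of 1 stereo elements differ; a double bond is drawn Z in compound 3 and E in compound 4: a double bond is drawn Z in compound 3 and E in compound 4. Among the compounds with values here, no measured pair shows such a change. Compound 2, also drawn E, gives > 10000 nM, which is a limit. No step beyond the scatter is expected in this assay, and a further limit is likely. The estimated move is a step that the limit leaves unreadable from compound 3 to compound 4. Compound 4 is expected at 12000 nM, with an estimated range of 4000 nM to 30000 nM.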

Compound 4, half-maximal inhibitory concentration: > 10000 nM
Compound 4 was reported as a limit; the forecaster's own chance of this, stated with the estimate: 65%; the middle value lies beyond the limit too.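

Within the data shown here, compound 2, compound 3 and compound 4 all sit at a limit in this assay, and no step among them can be read. Still open, going by these compounds, is whether double-bond configuration or 3-methylbut-2-en-1-yl in place of 1,1-dimethylprop-2-en-1-yl changes the read-out at all.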